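The source may hold more compounds than are shown below. What is called first, only, known or untested is meant among the compounds shown, and "the series" means these compounds.

Among the measured compounds shown here, in a functional assay for inhibition, with Homo sapiens as the target (on this read-out higher numbers stand for weaker binding and lower numbers for tighter binding), compound 2 `CC(C)(Oc1ccccc1Br)C1OCC(C/C=C\CCC(=O)O)C(c2cccnc2)O1` gives 63.1 nM and compound 1 `CC(C)(C)c1ccc(OC(C)(C)C2OCC(C/C=C\CCC(=O)O)C(c3cccnc3)O2)cc1` gives 1910 nM, so compound 2 holds the lower of the two numbers so far. Compound 3 `CC(C)(Oc1ccc(F)cc1[N+](=O)[O-])C1OCC(C/C=C\CCC(=O)O)C(c2cccnc2)O1` keeps the core of compound 2 and changes one group: 4-fluoro-2-nitrophenyl in place of 2-bromophenyl on an oxygen on a saturated carbon. That is 4-fluoro-2-nitrophenyl in place of 2-bromophenyl on an oxygen on a saturated carbon. For the measured compounds named here, only one measured step bears on this place, a 30-fold lower number from compound 1 to compound 2 (1.48 log units; beyond the scatter), a large step that brought in the 2-bromophenyl group in place of 4-(tert-butyl)phenyl. Going by the values given here, it shows that the number can move strongly with the group here, but no measured compound carries a nitro or fluoro group. A step of that size is not expected, and the expected change is a modest rise, an estimated 1.4-fold higher number from compound 2 to compound 3 (0.15 log units; within the scatter). The estimate in this assay for compound 3 is 90 nM, with an expected range of 25 nM to 330 nM.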

Compound 3, dissociation constant: 2.51 nM
Estimate against measurement, compound 3: 36-fold (1.55 log units) above; measured number outside the range, below it.
By their numbers in this assay, from the lowest: compound 3; then compound 2; then compound 1.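

In this assay, the change to 4-fluoro-2-nitrophenyl gives a 25-fold lower number from compound 2 to compound 3 (1.40 log units; beyond the scatter), so the 2-bromophenyl group did not mark the low end of the number at this place on an oxygen on a saturated carbon. Measured against the 4-(tert-butyl)phenyl group, the change gives a 760-fold lower number from compound 1 to compound 3 (2.88 log units; beyond the scatter), which shows that the choice of aryl group here can shift the number far more than the first step alone showed. No measured evidence accounts for either step.

The nitro and fluoro groups enter together, so the compounds shown leave open how the step divides between them. They also leave open whether an amine or a nitrile in place of the nitro group would keep the number this low.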